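Swapping the Cyanoguanidine Ring for an Aminothiazole

The source may hold more compounds than are shown below. What is called first, only, known or untested is meant among the compounds shown, and "the series" means these compounds.

The measured compounds, all with the same core and the same branched chain:
compound 1, `CC(C)C(Cc1ncc[nH]1)c1ccc(-c2ccc3cccc(F)c3c2)[nH]c1=O`, gives 11 nM in an assay on CHO cells for displacement of a labelled ligand from prostaglandin E2 receptor EP3 subtype (Homo sapiens), read by radioligand binding; a higher number here means a weaker inhibitor, a lower number a stronger inhibitor;
compound 2, `CC(C)C(c1ncco1)c1ccc(-c2ccc3cccc(F)c3c2)[nH]c1=O`, gives 24 nM in this assay;
compound 3, `CC(C)C(c1ccc(-c2ccc3cccc(F)c3c2)[nH]c1=O)N1CCN/C1=N\C#N`, gives 23 nM in this assay.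

Compound 3 has the second highest number of the three. Its nearest neighbour is compound 2, the two lying within the scatter of each other; compound 1 sits furthest off, with a 2.1-fold higher number from compound 1 to compound 3 (0.32 log units; beyond the scatter).

Compound 4, `CC(C)C(c1cnc(N)s1)c1ccc(-c2ccc3cccc(F)c3c2)[nH]c1=O`, is not yet measured. It differs from compound 3 in one place: a group of 6 heavy atoms (3 carbon, 2 nitrogen, 1 sulfur; one five-membered aromatic ring with 2 hetero atoms) in place of a group of 8 heavy atoms (4 carbon, 4 nitrogen; one five-membered non-aromatic ring with 2 hetero atoms), on a saturated chain carbon bound to an aromatic carbon and a saturated chain carbon. Among the compounds with values here, two measured steps bear on this. The step of a 1.0-fold lower number from compound 2 to compound 3 (0.02 log units; within the scatter) shows that a five-membered aromatic ring in place of the non-aromatic ring changed little, while a 2.2-fold higher number from compound 1 to compound 2 (0.34 log units; beyond the scatter) shows that a ring bound directly to the chain carbon, compared with one carried on an extra carbon, gave a modestly higher number. The expected step is therefore small: a 1.3-fold lower number from compound 3 to compound 4 (0.11 log units; within the scatter), an estimate rather than a measurement.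

Compound 4 is thus expected at about 18 nM, within 7 nM to 45 nM.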

Compound 4, inhibition constant: 16 nM
Compound 4: middle estimate off by 1.1-fold (0.05 log units), on the high side; low and high end bracket the measured number.
By their numbers in this assay, from the lowest: compounds 1, 4, 3 and 2 (each within the scatter of the next, the first and the last beyond it).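

With 2-amino-1,3-thiazol-5-yl on this saturated chain carbon, a ring carrying sulfur and an amino group enters the series, and its exchange for the non-aromatic ring gives a 1.4-fold lower number from compound 3 to compound 4 (0.16 log units; within the scatter). The same group also gives a 1.5-fold lower number from compound 2 to compound 4 (0.18 log units; within the scatter) and a 1.5-fold higher number from compound 1 to compound 4 (0.16 log units; within the scatter), so compound 4 lies within the scatter of all three earlier compounds in this assay, even though compound 1 and compound 2 lie beyond the scatter of each other. Nothing available here speaks to the reason these differently built groups give such close numbers.

Still open, going by these compounds, is what a plain 1,3-thiazol-5-yl ring without the amino group, or a methylamino group in place of the amino group, would give. On these data alone, all four compounds also share the same branched chain, so the effect of a longer chain there remains open too.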